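The source may report more compounds than this note shows. Statements on the series, on what has been measured and on what is new or still open speak of the compounds shown alone.

Working notes on the series. Compound 1 `O=C(/N=C(/NC(=O)c1cc(-c2ccccc2)nc2ccccc12)[Se]Cc1ccccc1)c1cc(-c2ccccc2)nc2ccccc12` and compound 2 `CS/C(=N\C(=O)c1cc(-c2ccccc2)nc2ccccc12)NC(=O)c1cc(-c2ccccc2)nc2ccccc12` share one core and differ only at the carbon with a double bond to nitrogen. In an ADME assay on MCF-10A cells (Homo sapiens) for cytotoxicity, read by MTT assay, with a stated time of 72 h (a lower number here means a stronger inhibitor of growth, a higher number a weaker inhibitor of growth), compound 1 gives 45600 nM, while compound 2 gives 540 nM; the step of an 84-fold lower number from compound 1 to compound 2 (1.93 log units; beyond the scatter) is the only one measured so far, and it leaves compound 2 as the lower of the two numbers. Compound 3 `C[Se]/C(=N\C(=O)c1cc(-c2ccccc2)nc2ccccc12)NC(=O)c1cc(-c2ccccc2)nc2ccccc12` carries the change (a group of 2 heavy atoms (1 carbon, 1 selenium; no ring) in place of a group of 2 heavy atoms (1 carbon, 1 sulfur; no ring), on a carbon with a double bond to nitrogen). Within the data shown here, the one measured step does not isolate this exchange: it replaces selenium by sulfur and a benzyl group by a methyl at the same time, so its size cannot be credited to the selenium alone. With the benzyl-to-methyl part already present in compound 2, the expected step of a 1.3-fold higher number from compound 2 to compound 3 (0.11 log units; within the scatter) is small, within the scatter, with no clear direction. Compound 3 is therefore expected near 700 nM in this assay, with a range from 250 nM to 2500 nM.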

Compound 3, concentration for total growth inhibition: 20100 nM
Beside the measured number, compound 3's estimate is 29-fold (1.46 log units) below it, and the stated range ends below it.
By their numbers in this assay, from the lowest: compound 2; then compound 3; then compound 1.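

In this assay, the selenium-for-sulfur exchange on the carbon with a double bond to nitrogen now stands alone, with the methyl group held constant, and it is large: a 37-fold higher number from compound 2 to compound 3 (1.57 log units; beyond the scatter). With selenium held constant, hydrogen in place of phenyl gives a much smaller a 2.3-fold lower number from compound 1 to compound 3 (0.36 log units; beyond the scatter), so most of an 84-fold lower number from compound 1 to compound 2 (1.93 log units; beyond the scatter) follows the exchange of selenium for sulfur rather than the loss of the phenyl. Among these compounds, no experimental information here bears on why this single atom exchange moves the number so far.

The compounds shown leave open whether the gap between sulfur and selenium persists with a benzylsulfanyl group, as sulfur appears here only with methyl. On these data alone, how a methoxy group or an amine on this carbon would read also remains open.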